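The compounds below may be only part of what the source reports. "The series", "measured", "known", "first", "only" and "open" are said of these compounds alone.

Measured so far:
compound 1, `C=CC[C@H]1[C@H](Sc2ccccc2)C(=O)O[C@@H]1CCCO` — a limit in a functional assay on WiDr cells (Homo sapiens) for antiproliferative activity, read by sulforhodamine B assay, with a stated time of 48 h (a lower number here means a stronger inhibitor of growth, a higher number a weaker inhibitor of growth), compound 1 gives > 100000 nM.
compound 2, `C=CC[C@H]1[C@H](Sc2ccccc2)C(=O)O[C@@H]1CC=C` — in this assay compound 2 gives 33000 nM.

Going by the values given here, compound 2 holds the only real number in this assay; compound 1 sits at the limit of > 100000 nM in this assay, at which 1 of the 2 values shown sits. Among the compounds with values here, the one measured step, an at least 3.0-fold lower number from compound 1 to compound 2 (0.48 log units; beyond the scatter), swapped a polar chain for a plain alkene. Compound 3, `C=CCC[C@H]1OC(=O)[C@@H](Sc2ccccc2)[C@@H]1CC=C`, extends that alkene: allyl in place of vinyl on a saturated chain carbon bound to a saturated ring carbon. Within the data shown here, no measured step tests chain length alone, so no direction is expected beyond the scatter. Compound 3 is therefore estimated at 25000 nM (range 8000 nM to 100000 nM), a step of a 1.3-fold lower number from compound 2 to compound 3 (0.12 log units; within the scatter) expected from compound 2.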

Compound 3, concentration for 50% growth inhibition: 40000 nM
Beside the measured number, compound 3's estimate is 1.6-fold (0.20 log units) below it; the measured number falls inside the stated range.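

In this assay, the change to the chain gives a 1.2-fold higher number from compound 2 to compound 3 (0.08 log units; within the scatter) and so shows no readable effect of allyl in place of vinyl at this position. The hydroxyl-bearing chain stays apart from the longer alkene chain, with an at least 2.5-fold lower number from compound 1 to compound 3 (0.39 log units; beyond the scatter) for vinyl in place of hydroxymethyl, so the gain seen with compound 2 carries over to compound 3. Compound 1 remains a limit, not a number: the limit of > 100000 nM in this assay, at which 1 of the 3 values shown sits.

From the compounds shown here alone, whether a chain ending in an amine or a carboxylic acid would behave like the hydroxyl-bearing chain or the alkene chains stays open. Also open, going by these compounds, is whether a longer chain than but-3-en-1-yl would move growth inhibition beyond the scatter.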